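The compounds below may be only part of what the source reports. "The series", "measured", "known", "first", "only" and "open" are said of these compounds alone.

Compounds measured so far:
Compound 1, `O=S(=O)(c1ccccc1)c1nc2ccccc2nc1Nc1ccc(F)cc1`: 14200 nM
Compound 2, `COc1cc(Nc2nc3ccccc3nc2S(=O)(=O)c2ccc(Br)cc2)cc(OC)c1`: 18200 nM
Compound 3, `Nc1ccc(Nc2nc3ccccc3nc2S(=O)(=O)c2ccc(Br)cc2)cc1`: 2330 nM

In a functional assay on PC-3 cells (Homo sapiens) for cytotoxicity, read by MTT assay, with a stated time of 72 h (a higher number here means a weaker inhibitor, a lower number a stronger inhibitor), compound 3 gives the lowest of the three numbers, and both of the others lie beyond the scatter from it. Within the data shown here, the only single-point step so far is a 7.8-fold lower number from compound 2 to compound 3 (0.89 log units; beyond the scatter). Compound 4, `O=S(=O)(c1ccc(Br)cc1)c1nc2ccccc2nc1Nc1ccc(F)cc1`, has not yet been measured. It differs from compound 3 by fluoro in place of amino on an aromatic carbon. Among the measured compounds shown here, no measured step covers exactly this change. What the numbers do show is that compound 1, which also carries a 4-fluorophenyl group, gives 14200 nM in this assay, while compound 3 with its 4-aminophenyl group gives 2330 nM; and that swapping the 3,5-dimethoxyphenyl group of compound 2 for the 4-aminophenyl group lowered the number. On that basis the expectation for compound 4 is a move back toward the higher numbers, a step of a 4.7-fold higher number from compound 3 to compound 4 (0.67 log units; beyond the scatter). Compound 4 is therefore estimated at 11000 nM, with a range from 4000 nM to 30000 nM.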

Compound 4, half-maximal inhibitory concentration: 9160 nM
Beside the measured number, compound 4's estimate is 1.2-fold (0.08 log units) above it, within the range that was stated.
By their numbers in this assay, from the lowest: compound 3; then compounds 4, 1 and 2 (each within the scatter of the next).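

Swapping amino for fluoro, with the rest of the molecule unchanged, gives a 3.9-fold higher number from compound 3 to compound 4 (0.59 log units; beyond the scatter) in this assay, so the low number of compound 3 goes with its 4-aminophenyl group and not with the bromo it shares with compound 4. Placing bromo in place of hydrogen gives only a 1.6-fold lower number from compound 1 to compound 4 (0.19 log units; within the scatter), a step within the scatter, so this change has no readable effect here. Likewise, 4-fluorophenyl in place of 3,5-dimethoxyphenyl gives a 2.0-fold lower number from compound 2 to compound 4 (0.30 log units; within the scatter), also within the scatter, which leaves the 4-aminophenyl group as the only one of the three on that nitrogen to stand apart.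

Nothing at hand explains why the amino group goes with the lower number. From the compounds shown here alone, whether that number belongs to amino alone stays open, and a hydroxyl, a methylamino group or an acetamide in its place would test this.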